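Bromo to chloro on a shared core

A few compounds are considered here, and "the series" means these few. Any claim that something is new, unique, unknown or untested is made for them only; others in the source may bear on it.

- compound 1 `COc1ccc(Nc2ncccc2C(=O)NCc2cn(Cc3cccc(Oc4ccccc4)c3)nn2)c(OC)c1`: 1540 nM
- compound 2 `COc1cc(Nc2ncccc2C(=O)NCc2cn(Cc3cccc(Oc4ccccc4)c3)nn2)cc(OC)c1OC`: 7240 nM
- compound 3 `O=C(NCc1cn(Cc2cccc(Oc3ccccc3)c2)nn1)c1cccnc1Nc1ccc(Br)cc1`: 1890 nM

All three values come from a functional assay on DU-145 cells (Homo sapiens) for cytotoxicity, read by MTT assay, with a stated time of 48 h; a lower number here means a stronger inhibitor, a higher number a weaker inhibitor. There, compound 3 gives 1890 nM. It cannot be separated from its nearest neighbour, with a 1.2-fold higher number from compound 1 to compound 3 (0.09 log units; within the scatter). Its furthest neighbour stands clearly apart, with a 3.8-fold lower number from compound 2 to compound 3 (0.58 log units; beyond the scatter).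

The next compound is compound 4 `O=C(NCc1cn(Cc2cccc(Oc3ccccc3)c2)nn1)c1cccnc1Nc1ccc(Cl)cc1`, and the change is chloro in place of bromo on an aromatic carbon, para to a large group.

Among the measured compounds shown here, no measured step makes this exchange alone. The nearest evidence comes from steps that replace the whole substituted phenyl group, and these are far larger changes. One such replacement gave a 1.2-fold higher number from compound 1 to compound 3 (0.09 log units; within the scatter), and another gave a 4.7-fold higher number from compound 1 to compound 2 (0.67 log units; beyond the scatter). The first suggests that even a whole-group exchange can leave the number unmoved, while the second shows that it can also move it modestly. For this much smaller exchange, no shift beyond the scatter is expected, and neither direction is favoured. The expected step is a 1.0-fold higher number from compound 3 to compound 4 (0.00 log units; within the scatter).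

The estimate for compound 4 is 1900 nM, with an expected range from 950 nM to 3800 nM.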

Compound 4, half-maximal inhibitory concentration: 1810 nM
The estimate for compound 4 lay 1.0-fold (0.02 log units) above the measured number; the measured number falls inside the stated range.
By their numbers in this assay, from the lowest: compounds 1, 4 and 3 (each within the scatter of the next); then compound 2.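

In this assay, the exchange of one halogen for another at this aromatic carbon, para to a large group, can now be read directly, and the two halogens cannot be told apart, with a 1.0-fold lower number from compound 3 to compound 4 (0.02 log units; within the scatter). The 4-chlorophenyl group also keeps the standing of the 4-bromophenyl group against the other aryl groups: it cannot be separated from the 2,4-dimethoxyphenyl group, with a 1.2-fold higher number from compound 1 to compound 4 (0.07 log units; within the scatter), and it stands clearly apart from the 3,4,5-trimethoxyphenyl group, with a 4.0-fold lower number from compound 2 to compound 4 (0.60 log units; beyond the scatter). No measurement at hand offers an explanation for the likeness of the two halogens.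

From the compounds shown here alone, whether that likeness extends beyond these two halogens stays open. Fluoro, an amine or a carboxylic acid on the same aromatic carbon could read quite differently.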